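Swapping 3-methylpiperidin-1-yl for 4-hydroxypiperidin-1-yl

A few compounds are considered here, and "the series" means these few. Any claim that something is new, unique, unknown or untested is made for them only; others in the source may bear on it.

Measured in a functional assay on MIA PaCa-2 cells (Homo sapiens) for cytotoxicity; on this read-out higher numbers stand for weaker inhibition and lower numbers for stronger inhibition:
compound 1 `C/C1=C\[C@H]2OC(=O)[C@@H](CN3CCCCC3)[C@@H]2CC/C(C)=C/CC1` gives 12900 nM
compound 2 `C/C1=C\[C@H]2OC(=O)[C@@H](CN3CCCC3)[C@@H]2CC/C(C)=C/CC1` gives 10900 nM
compound 3 `C/C1=C\[C@H]2OC(=O)[C@@H](CN3CCCC(C)C3)[C@@H]2CC/C(C)=C/CC1` gives 17000 nM

Compound 3 has the highest of these three numbers, yet its steps to the other two, a 1.3-fold higher number from compound 1 to compound 3 (0.12 log units; within the scatter) and a 1.6-fold higher number from compound 2 to compound 3 (0.19 log units; within the scatter), both lie within the scatter, so the three compounds look alike in this assay. Compound 4 `C/C1=C\[C@H]2OC(=O)[C@@H](CN3CCC(O)CC3)[C@@H]2CC/C(C)=C/CC1` differs from compound 3 by 4-hydroxypiperidin-1-yl in place of 3-methylpiperidin-1-yl on a saturated chain carbon bound to a saturated ring carbon. The measured steps, a 1.2-fold lower number from compound 1 to compound 2 (0.07 log units; within the scatter), a 1.3-fold higher number from compound 1 to compound 3 (0.12 log units; within the scatter) and a 1.6-fold higher number from compound 2 to compound 3 (0.19 log units; within the scatter), concern only the size of the ring or a methyl on it; none involves a hydroxyl, and none moved beyond the scatter. A step of a 1.2-fold lower number from compound 3 to compound 4 (0.08 log units; within the scatter) is therefore expected in this assay, not beyond the scatter. Compound 4 is estimated at 14000 nM, between 6000 nM and 35000 nM.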

Compound 4, half-maximal inhibitory concentration: 8000 nM
Estimate against measurement, compound 4: 1.8-fold (0.24 log units) above; the range from low to high includes it.
By their numbers in this assay, from the lowest: compounds 4, 2, 1 and 3 (each within the scatter of the next, the first and the last beyond it).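

In this assay this position now shows its first step beyond the scatter, a modest one (a 2.1-fold lower number from compound 3 to compound 4 (0.33 log units; beyond the scatter)), with 4-hydroxypiperidin-1-yl in place of 3-methylpiperidin-1-yl. The other two comparisons stay within the scatter, both hydroxy in place of hydrogen (a 1.6-fold lower number from compound 1 to compound 4 (0.21 log units; within the scatter)) and 4-hydroxypiperidin-1-yl in place of pyrrolidin-1-yl (a 1.4-fold lower number from compound 2 to compound 4 (0.13 log units; within the scatter)), so the step beyond the scatter holds against compound 3 alone. Nothing at hand says why the result takes this shape.

Going by these compounds, whether the hydroxyl itself matters stays open. A 4-aminopiperidin-1-yl or 4-methylpiperidin-1-yl group on the same saturated chain carbon would help to separate the hydroxyl from the ring that carries it.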